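Carbamoyl for hydroxymethyl on a benzimidazole-linked pyridine series

The source may hold more compounds than are shown below. What is called first, only, known or untested is meant among the compounds shown, and "the series" means these compounds.

Measured so far:
- compound 1 `Cc1cccnc1-c1nc2ccccc2[nH]1`: 17%
- compound 2 `Cc1ccnc(-c2nc3ccccc3[nH]2)c1`: -4%
- compound 3 `OCc1cccc(-c2nc3ccccc3[nH]2)n1`: -13%

All three were run in a functional assay on the whole organism with Rattus norvegicus as the target, read by paw edema, with a stated time of 3 h, at a dose of 100 mg/kg by the oral route; on this read-out higher numbers stand for more inhibition at the one dose given (going by the name of the read-out) and lower numbers for less inhibition. Compound 1 gives 17%, compound 2 gives -4%, and compound 3 gives -13%. Compound 3 stands beyond the scatter below compound 1, while compound 3 and compound 2 are within the scatter of each other, so nothing separates those two. Within the data shown here, no pair among the measured compounds differs in a single place, so no measured step is available to guide the next change.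

Compound 4 `NC(=O)c1cccc(-c2nc3ccccc3[nH]2)n1` differs from compound 3 by carbamoyl in place of hydroxymethyl on an aromatic carbon. The exchange keeps the count of hydrogen-bond donors and acceptors and adds one heavy atom and one double bond outside aromatic rings. With no measured step of this kind in the series, no direction can be read from the data. The step in this assay from compound 3 is expected to stay within the scatter, a number 13 percentage points higher from compound 3 to compound 4 (beyond the scatter). Compound 4 is therefore estimated at 0%, in the range -20% to 25%.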

Compound 4, a percentage reported as inhibition, in the whole organism at one dose (the size of the read-out at that dose, not a potency): 13%
Beside the measured number, compound 4's estimate is 13 percentage points below it; measured number inside the range.
By their numbers in this assay, from the lowest: compounds 3 and 2 (each within the scatter of the next); then compounds 4 and 1 (each within the scatter of the next).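

Among these compounds, the exchange of hydroxymethyl for carbamoyl on the aromatic carbon next to the ring nitrogen gives, in this assay, a number 26 percentage points higher from compound 3 to compound 4 (beyond the scatter) and is the only measured change in one place. It shows that the read-out at this one dose responds to the group at this position and is not set by the shared core alone, which compounds 1, 2 and 3, differing in more than one place, could not show. No measured evidence bears on what lies behind the step.

A single step cannot separate the contribution of the carbonyl from that of the amide nitrogen. From the compounds shown here alone, whether a carboxylic acid, a methyl ester or an aminomethyl group on the same carbon would move the number the same way remains open.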